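This account rests on a few compounds, and the source may have more. Where it says the series, first, only, none or still open, it means among the compounds named here.

Values measured so far in a functional assay on HeLa cells (Homo sapiens) for inhibition, read by MTT assay, with a stated time of 48 h (on this read-out lower numbers stand for stronger inhibition and higher numbers for weaker inhibition), are these
- compound 1 `c1ccc(C(c2c[nH]c3ccccc23)c2c[nH]c3ccccc23)cc1` gives 21800 nM
- compound 2 `COc1ccc(OC)c(C(c2c[nH]c3ccc(Br)cc23)c2c[nH]c3ccc(Br)cc23)c1` gives 5100 nM

Compound 1 has the higher of these two numbers, which makes it the weaker inhibitor of the pair, and the gap to compound 2 lies beyond the usual scatter. The next compound to be tested is compound 3 `CC(c1ccccc1)(c1c[nH]c2ccccc12)c1c[nH]c2ccccc12` and it keeps the core of compound 1. Among the measured compounds shown here, the one change is a methyl in place of hydrogen on a saturated chain carbon bound to three aromatic carbons and no measured pair shows this change on its own. With so little to go on, no clear direction can be favoured. The expected step of a 1.1-fold lower number from compound 1 to compound 3 (0.04 log units; within the scatter) stays within the scatter. For compound 3 the estimated value is 20000 nM in this assay with an expected range of 8000 nM to 50000 nM as a guide.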

Compound 3, half-maximal inhibitory concentration: 4200 nM
For compound 3 the middle estimate is 4.8-fold (0.68 log units) above the measured one; the measured number lies below the stated range.
By their numbers in this assay, from the lowest: compounds 3 and 2 (each within the scatter of the next); then compound 1.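

In this assay the swap of hydrogen for methyl on a saturated chain carbon bound to three aromatic carbons gives a 5.2-fold lower number from compound 1 to compound 3 (0.72 log units; beyond the scatter) and so shows that this position responds to substitution: a single added carbon, with the rest of the core of compound 1 unchanged, moves the number beyond the scatter. Among the compounds shown here, compound 1 and compound 2 differ in several places, so this pair is the first in which one change can be read on its own. No measurement here explains the step.

From the compounds shown here alone, whether an ethyl group, a longer chain, a hydroxyl or an amine on this carbon would lower the number further, or raise it again, remains open. Going by these compounds, it is also open whether the methyl would have a similar effect on the core of compound 2.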